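A New Substituent on the Amine Nitrogen of Compound 1

The source may hold more compounds than are shown below. What is called first, only, known or untested is meant among the compounds shown, and "the series" means these compounds.

Of the compounds shown here, three built on a shared core have been measured in a functional assay on HeLa cells (Homo sapiens) for antiproliferative activity, with a stated time of 24 h; a higher number here means a weaker inhibitor, a lower number a stronger inhibitor. Compound 1 `NC(=O)c1c(NC(=O)c2ccccc2Cl)sc2c1CCN(Cc1ccc([N+](=O)[O-])cc1)C2` carries a 4-nitrobenzyl group on an amine nitrogen in a ring, and in this assay compound 1 gives 46100 nM. Compound 3 `NC(=O)c1c(NC(=O)c2cccc([N+](=O)[O-])c2)sc2c1CCN(Cc1ccc(Cl)cc1Cl)C2` gives 33000 nM in this assay, a number that lies within the scatter of the value of compound 1, so the two cannot be told apart. Compound 2 `NC(=O)c1c(NC(=O)c2ccc(C(F)(F)F)cc2)sc2c1CCN(Cc1ccccc1F)C2` reaches only a limit of this assay, > 50000 nM. Taken together, (the limit of > 50000 nM in this assay, at which 1 of the 3 values shown sits), and all three compounds are weak inhibitors.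

Compound 4 `COc1ccc(NC(=S)N2CCc3c(sc(NC(=O)c4ccccc4Cl)c3C(N)=O)C2)cc1` has not yet been measured. It differs from compound 1 in one place: a group of 11 heavy atoms (8 carbon, 1 nitrogen, 1 oxygen, 1 sulfur; one six-membered aromatic ring of carbon only) in place of a group of 10 heavy atoms (7 carbon, 1 nitrogen, 2 oxygen; one six-membered aromatic ring of carbon only), on an amine nitrogen in a ring. Going by the values given here, no step between measured compounds concerns this position, so there is no measured step to guide the expectation. The step of a 1.2-fold lower number from compound 1 to compound 4 (0.06 log units; within the scatter) is expected to be small, in either direction, and probably not beyond the scatter. This rests on compound 1 giving 46100 nM and on the two other measured compounds remaining in the same weak region. Compound 4 is therefore estimated at 40000 nM, between 15000 nM and 110000 nM, with a fair chance that this assay reports only a limit.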

Compound 4, half-maximal inhibitory concentration: 36400 nM
The estimate for compound 4 lay 1.1-fold (0.04 log units) above the measured number; the measured number falls inside the stated range.
By their numbers in this assay, from the lowest: compounds 3, 4 and 1 (each within the scatter of the next). At a limit, above all of these: compound 2.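

In this assay, going by these compounds alone, replacing the 4-nitrobenzyl group on the amine nitrogen in a ring gives a 1.3-fold lower number from compound 1 to compound 4 (0.10 log units; within the scatter), the first measured step at this position. The entering group has no common name, and it brings a sulfur atom and a hydrogen-bond donor that the 4-nitrobenzyl group lacks, yet this single exchange leaves the number within the scatter, so the pair gives no sign that the change matters in this assay and credits neither feature with any effect. The weak region also still reaches a limit of the assay, held by compound 2: the limit of > 50000 nM in this assay, at which 1 of the 4 values shown sits.

Going by these compounds, whether any group on this nitrogen can move the number beyond the scatter remains open, as does whether the same small step would hold alongside the other amide groups carried by compound 2 and compound 3. A urea with oxygen in place of the sulfur, a free secondary amine or a short alkyl chain at this position could each test how far the result extends beyond this one pair.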